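The source may report more compounds than this note shows. Statements on the series, on what has been measured and on what is new or still open speak of the compounds shown alone.

compound 1 `O=C(CCCc1nc2ccccc2c(=O)[nH]1)N/N=C/c1cc(O)c(O)c(O)c1` gives 78000000 nM
compound 2 `COc1cc(/C=N/NC(=O)CCc2nc3ccccc3c(=O)[nH]2)cc(OC)c1OC` gives 85000000 nM
compound 3 `O=C(CCc1nc2ccccc2c(=O)[nH]1)N/N=C/c1ccc(Cl)cc1` gives 381000000 nM

In a physicochemical assay, read by spectrophotometry, with a stated time of 30 min (on this read-out higher numbers stand for weaker inhibition and lower numbers for stronger inhibition), compound 1 sits within the usual scatter of compound 2, while compound 3 stands clearly higher. Compound 4 `COc1cc(/C=N/NC(=O)CCCc2nc3ccccc3c(=O)[nH]2)cc(O)c1O` is compound 1 with one change, (methyl in place of hydrogen on an oxygen on an aromatic ring), methyl in place of hydrogen on an oxygen on an aromatic ring, so one hydroxy becomes methoxy. For the measured compounds named here, no measured pair differs in one place alone, so this step has no direct precedent. Compound 2 carries methoxy groups, along with a different chain, and still gives 85000000 nM, so no step beyond the scatter, in either direction, is expected in this assay. The estimated change is small, a 1.0-fold higher number from compound 1 to compound 4 (0.01 log units; within the scatter). For compound 4 the expected value is 80000000 nM, with an estimated range from 38000000 nM to 170000000 nM.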

Compound 4, half-maximal inhibitory concentration: 88000000 nM
Compound 4: the middle estimate sits 1.1-fold (0.04 log units) below what was measured; low and high end bracket the measured number.
By their numbers in this assay, from the lowest: compounds 1, 2 and 4 (each within the scatter of the next); then compound 3.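

In this assay, for the compounds shown here, the first comparison of two compounds differing in one place reads a 1.1-fold higher number from compound 1 to compound 4 (0.05 log units; within the scatter) and gives this position its first direct measure. This hydroxy on the aromatic ring can therefore become methoxy without a step beyond the scatter. Nothing available explains this result. From the compounds shown here alone, whether the other hydroxy groups on the ring would accept the same methyl remains open. So does the outcome of an ethyl on this oxygen, or of an amine in place of the hydroxy.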